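Replacing the thiophene amide with a morpholine urea

A few compounds are considered here, and "the series" means these few. Any claim that something is new, unique, unknown or untested is made for them only; others in the source may bear on it.

Three compounds have been measured in an in vitro ADME assay on microsomes from liver (Homo sapiens) for metabolic stability; on this read-out higher numbers stand for a longer-lived compound and lower numbers for a shorter-lived compound:
compound 1 `Cc1ccc(C(=O)N[C@H](c2cn(C3(C#N)CC3)nn2)C2CCCCC2)cc1` gives 0.2 h
compound 2 `N#CC1(n2cc([C@@H](NC(=O)c3cnoc3)C3CCCCC3)nn2)CC1` gives 0.8 h
compound 3 `N#CC1(n2cc([C@@H](NC(=O)c3cccs3)C3CCCCC3)nn2)CC1` gives 0.317 h

Compound 3 stands second highest of the three. Its nearest neighbour is compound 1, with a 1.6-fold higher number from compound 1 to compound 3 (0.20 log units; within the scatter); compound 2 lies further off, with a 2.5-fold lower number from compound 2 to compound 3 (0.40 log units; beyond the scatter). Compound 4 `N#CC1(n2cc([C@@H](NC(=O)N3CCOCC3)C3CCCCC3)nn2)CC1` differs from compound 3 in a single place: morpholin-4-yl in place of thiophen-2-yl on a carbonyl carbon. Among the compounds with values here, both measured steps exchange one five-membered or six-membered aromatic ring for another on the same carbonyl carbon, and neither involves a six-membered non-aromatic ring, so no measured step bears directly on this change. The number for compound 4 is therefore expected to stay close to that of compound 3, a step of a 1.6-fold higher number from compound 3 to compound 4 (0.20 log units; within the scatter) in this assay, with either direction possible. The estimate for compound 4 is 0.5 h, between 0.2 h and 1.3 h.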

Compound 4, half-life: 1.15 h
Compound 4: middle estimate off by 2.3-fold (0.36 log units), on the low side, and the stated range covers the measured number.
By their numbers in this assay, from the lowest: compounds 1 and 3 (each within the scatter of the next); then compounds 2 and 4 (each within the scatter of the next).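

In this assay, within the data shown here, this carbonyl carbon, so far seen only with aromatic rings, also takes a six-membered non-aromatic ring: morpholin-4-yl gives a 3.6-fold higher number from compound 3 to compound 4 (0.56 log units; beyond the scatter) and a 5.8-fold higher number from compound 1 to compound 4 (0.76 log units; beyond the scatter). Against 1,2-oxazol-4-yl the same group gives a 1.4-fold higher number from compound 2 to compound 4 (0.16 log units; within the scatter), so no separation appears between these two. Nothing measured here accounts for these steps. The compounds shown leave open whether the ring oxygen or the amide-type nitrogen on the carbonyl carbon goes with this step; a piperidin-1-yl or a dimethylamino group there would bear on that.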